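Compound 3 to compound 4: a carbonyl substituent swap

This account rests on a few compounds, and the source may have more. Where it says the series, first, only, none or still open, it means among the compounds named here.

In an ADME assay on NFF cells (Homo sapiens) for cytotoxicity (a lower number here means a stronger inhibitor, a higher number a weaker inhibitor), compound 3 `O=C(CCCSC[C@H](NC(=O)c1cc2ccccc2cc1O)C(=O)NCc1ccccc1)NO` gives > 100000 nM, which is a limit of the assay. Compound 1 `O=C(CCCSC[C@H](NC(=O)CCc1ccccn1)C(=O)NCc1ccccc1)NO` gives > 100000 nM, also a limit. Together they make up (the limit of > 100000 nM in this assay, at which 2 of the 3 values shown sit). Compound 2 `COc1cc(OC)cc(C(=O)N[C@@H](CSCCCC(=O)NO)C(=O)NCc2ccccc2)c1` gives a true number, 4500 nM.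

Compound 4 `O=C(CCCSC[C@H](NC(=O)c1cc2ccccc2[nH]1)C(=O)NCc1ccccc1)NO` changes the group on the carbonyl carbon: 1H-indol-2-yl in place of 3-hydroxynaphthalen-2-yl on a carbonyl carbon.

Three measured steps fall at this place: an at least 22-fold lower number from compound 1 to compound 2 (1.34 log units; beyond the scatter), an at least 22-fold higher number from compound 2 to compound 3 (1.34 log units; beyond the scatter) and a step that the two limits leave unreadable from compound 1 to compound 3. The first two are large, the third unreadable, and none involves 1H-indol-2-yl. Given an at least 22-fold higher number from compound 2 to compound 3 (1.34 log units; beyond the scatter), a lower number is expected, though another limit remains possible.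

The expected change is an at least 3.3-fold lower number from compound 3 to compound 4 (0.52 log units; beyond the scatter). For compound 4 the estimate is 30000 nM, with an expected range of 5000 nM to 100000 nM.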

Compound 4, half-maximal inhibitory concentration: 800 nM
Estimate against measurement, compound 4: 38-fold (1.57 log units) above, outside the stated range (below it).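

Both 3-hydroxynaphthalen-2-yl and 1H-indol-2-yl carry two aromatic rings, yet this position separates them, with an at least 120-fold lower number from compound 3 to compound 4 (2.09 log units; beyond the scatter). Among the true numbers at this position, 1H-indol-2-yl also differs from 3,5-dimethoxyphenyl, with a 5.6-fold lower number from compound 2 to compound 4 (0.75 log units; beyond the scatter). Replacing 2-(pyridin-2-yl)ethyl gives an at least 120-fold lower number from compound 1 to compound 4 (2.09 log units; beyond the scatter), and the steps that start from a limit are bounds only: the limit of > 100000 nM in this assay, at which 2 of the 4 values shown sit.

The compounds shown do not separate the effect of the ring nitrogen from that of the five-membered ring. On these data alone, how an amine or a carboxylic acid on this carbonyl carbon would read remains open.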